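This account rests on a few compounds, and the source may have more. Where it says the series, first, only, none or still open, it means among the compounds named here.

In an ADME assay on microsomes from liver (Mus musculus, strain CD-1) for metabolic stability, read by LC-MS, with a stated time of 60 min, tested at 20 uM (a lower number here means that the compound disappears faster, a higher number that the compound lasts longer), three compounds sharing a core have been measured. Compound 1 `CC(Sc1nc2nn(CC3COC3)cc2c(=O)n1-c1ccccc1)c1ccccc1` gives 0.317 h and compound 2 `COc1cccc(C(C)Sc2nc3c(cnn3C)c(=O)n2-c2ccccc2)c1` gives 0.1 h as its half-life. Compound 3 `CC(Sc1nc2nn(C3COC3)cc2c(=O)n1-c1ccccc1)c1ccccn1` reads > 1 h in this measurement, which is a limit of the assay and not a number. Compound 2 therefore holds the lower of the two actual numbers, and its gap to compound 1 lies beyond the usual scatter.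

Compound 4 `CC(Sc1nc2c(cnn2C)c(=O)n1-c1ccccc1)c1cccc(O)c1` has not yet been measured. It departs from compound 2 in one place (hydrogen in place of methyl on an oxygen on an aromatic ring): hydrogen in place of methyl on an oxygen on an aromatic ring, turning 3-methoxyphenyl into 3-hydroxyphenyl. Within the data shown here, no step between measured compounds covers this change, so the expectation rests on compound 2 alone, whose 0.1 h sits low and leaves more room to rise than to fall. The expected change is a 2.2-fold higher number from compound 2 to compound 4 (0.34 log units; beyond the scatter) and would be a modest rise in this assay that may not clear the scatter by much. Compound 4 is estimated at 0.22 h (expected range 0.08 h to 0.7 h) for its half-life.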

Compound 4, half-life: 0.0667 h
The estimate for compound 4 lay 3.3-fold (0.52 log units) above the measured number; the measured number lies below the stated range.
By their numbers in this assay, from the lowest: compounds 4 and 2 (each within the scatter of the next); then compound 1. At a limit, above all of these: compound 3.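

In this assay the change from 3-methoxyphenyl to 3-hydroxyphenyl now has a reading of its own, on a pair that differs in this one place (a 1.5-fold lower number from compound 2 to compound 4 (0.18 log units; within the scatter)). Hydrogen in place of methyl on an oxygen on an aromatic ring thus leaves the half-life of this pair within the scatter, and the change does not lift compound 4 clear of compound 2, so at this position the methoxy and hydroxy groups cannot be told apart in this measurement. Nothing shown here bears on why the pair reads this way.

The change is seen on this single pair, and the other compounds shown carry neither group, so it stays open whether it would read the same on another part of the series or with a different group on the shared core. Also open, on these data alone, is how an ethyl group or a longer chain on that oxygen would read, or an amine or a carboxylic acid in the place of the hydroxy group.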